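The source may hold more compounds than are shown below. What is called first, only, known or untested is meant among the compounds shown, and "the series" means these compounds.

Working notes on the series. In a functional assay (aorta) with Rattus norvegicus as the target (on this read-out higher numbers stand for higher potency (the scale is a negative logarithm) and lower numbers for lower potency), compound 1 `CC1(C)C=C(n2ccccc2=O)c2cc(C(=O)c3ccc(O)cc3)ccc2O1` gives 6.65 and stands second highest of the three measured numbers. Compound 3 `CC1(C)C=C(n2ccccc2=O)c2cc(C(=O)c3ccccc3C(F)(F)F)ccc2O1` gives 6.76, and the step of a number 0.11 log units higher from compound 1 to compound 3 (within the scatter) is within the scatter. Compound 2 `CC1(C)C=C(n2ccccc2=O)c2cc(C(=O)c3ccccc3[N+](=O)[O-])ccc2O1` gives 6.17, and the step of a number 0.48 log units lower from compound 1 to compound 2 (beyond the scatter) is beyond the scatter; the step of a number 0.59 log units higher from compound 2 to compound 3 (beyond the scatter) is likewise beyond the scatter. All three measured steps vary only the aryl group attached to the carbonyl carbon while keeping the carbonyl and the shared core.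

Compound 4 `CC1(C)C=C(n2ccccc2=O)c2cc(-c3ccncc3)ccc2O1` differs from compound 1 as follows: pyridin-4-yl in place of (4-hydroxyphenyl)carbonyl on an aromatic carbon. Among the compounds with values here, no measured step removes the carbonyl or replaces the whole (4-hydroxyphenyl)carbonyl with a directly attached aromatic ring, so the measured steps bear on the change only loosely. They show that changes on this position move this assay by modest amounts, as in a number 0.48 log units lower from compound 1 to compound 2 (beyond the scatter) and a number 0.11 log units higher from compound 1 to compound 3 (within the scatter). A modest step in either direction is therefore expected, with a wider uncertainty than for the measured steps, and the estimated step is a number 0.35 log units lower from compound 1 to compound 4 (beyond the scatter). For compound 4 the estimated value is 6.3, with an expected range from 5.6 to 7.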

Compound 4, logarithm of the reciprocal of the active concentration, log(1/C): 6.68
Estimate against measurement, compound 4: 0.38 log units below, within the range that was stated.
By their numbers in this assay, from the lowest: compound 2; then compounds 1, 4 and 3 (each within the scatter of the next).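

The step of a number 0.03 log units higher from compound 1 to compound 4 (within the scatter) shows that in this assay the whole (4-hydroxyphenyl)carbonyl can give way to a directly attached pyridin-4-yl without a change beyond the scatter. Within the data shown here, the earlier compounds all kept the carbonyl, so this is the first sign that neither the carbonyl nor a carbon-only aromatic ring is required on this aromatic carbon for a number in this range. The data give no measured property that would account for this result.

The compounds shown leave open whether the ring nitrogen of pyridin-4-yl contributes, which an unsubstituted phenyl or a pyridin-3-yl on the same carbon would test. They also leave open how a non-aromatic group, such as an amine or a carboxylic acid, would read out at this position.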